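The source may report more compounds than this note shows. Statements on the series, on what has been measured and on what is new or still open speak of the compounds shown alone.

Of the compounds shown here, three with a shared core have been measured in a functional assay on NIH3T3 cells (Mus musculus); a higher number here means that more compound is needed for the effect, a lower number that less compound is needed. Compound 1 `Cn1cncc1C(OCc1ccc(C#N)cc1C#Cc1cccc(O)c1)c1ccc(C#N)cc1` carries a 3-hydroxyphenyl on a triple-bonded carbon. In this assay compound 1 gives only a limit of the assay, > 0.1 nM. Compound 2 `Cn1cncc1C(OCc1ccc(C#N)cc1C#Cc1ccccn1)c1ccc(C#N)cc1` carries a pyridin-2-yl in that place. In this assay compound 2 likewise gives only a limit, > 0.1 nM. Compound 3 `CCCCCCC#Cc1cc(C#N)ccc1COC(c1ccc(C#N)cc1)c1cncn1C` carries a hexyl in that place. In this assay compound 3 too gives only a limit, > 0.1 nM. Compound 3 thus stands where every shown value stands, at the limit of > 0.1 nM in this assay, at which 3 of the 3 values shown sit, and the steps a step that the two limits leave unreadable from compound 1 to compound 2, a step that the two limits leave unreadable from compound 1 to compound 3 and a step that the two limits leave unreadable from compound 2 to compound 3 cannot be sized.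

Compound 4 `Cn1cncc1C(OCc1ccc(C#N)cc1C#Cc1ccc(C#N)cc1)c1ccc(C#N)cc1` differs from compound 3 in one place: 4-cyanophenyl in place of hexyl on a triple-bonded carbon. Among the compounds with values here, none of the measured steps has a readable size, so no size or direction of step in this assay can be drawn from them; the only guide is that all three values so far are limits.

Compound 4 is therefore expected to give in this assay about 0.5 nM, estimated to lie between 0.1 nM and 10 nM, quite possibly again as a limit. The estimated step that the limit leaves unreadable from compound 3 to compound 4 is an expectation only.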

Compound 4, half-maximal effective concentration: 11.6 nM
For compound 4 the middle estimate is 23-fold (1.37 log units) below the measured one; measured number above the stated range.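

In this assay, the steps to compound 4 from compound 1, compound 2 and compound 3 cannot be read, as each of these three stands only at a limit: the limit of > 0.1 nM in this assay, at which 3 of the 4 values shown sit.

From the compounds shown here alone, whether compound 4 needs more or less compound than any of them remains open.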